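Adding a Nitro Group to Two Related Cores

The compounds below may be only part of what the source reports. "The series", "measured", "known", "first", "only" and "open" are said of these compounds alone.

Measured so far in an ADME assay on BHK cells (Mesocricetus auratus) for cytotoxicity, read by MTT assay, with a stated time of 96 h; a higher number here means that more compound is tolerated, a lower number that less compound is tolerated:
compound 1 `COc1ccc(-c2nc3cc(Cl)c(Cl)cc3[nH]2)cc1` gives 18000 nM
compound 2 `COc1ccc(-c2nc3cc(C(F)(F)F)ccc3[nH]2)cc1` gives > 100000 nM
compound 3 `COc1ccc(-c2nc3cc(Cl)c(Cl)cc3[nH]2)c([N+](=O)[O-])c1` gives 80000 nM

Compound 1 and compound 3 share one core and differ only by nitro in place of hydrogen on an aromatic carbon. That change made a 4.4-fold higher number from compound 1 to compound 3 (0.65 log units; beyond the scatter). The value of compound 2 is not a number but a limit of this assay, namely (the limit of > 100000 nM in this assay, at which 1 of the 3 values shown sits). How the core of compound 2 differs from the core of compound 1 is not broken down here. Compound 4 `COc1ccc(-c2nc3cc(C(F)(F)F)ccc3[nH]2)c([N+](=O)[O-])c1` differs from compound 2 by nitro in place of hydrogen on an aromatic carbon, the same change as from compound 1 to compound 3. The expected step is a step that the limit leaves unreadable from compound 2 to compound 4, resting on a 4.4-fold higher number from compound 1 to compound 3 (0.65 log units; beyond the scatter) and on compound 2 already sitting at the limit. Compound 4 is therefore expected to give about 150000 nM, most likely again only as a limit, between 60000 nM and 400000 nM.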

Compound 4, half-maximal cytotoxic concentration: 100000 nM
Estimate against measurement, compound 4: 1.5-fold (0.18 log units) above, and the stated range covers the measured number.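

In this assay, compound 2 gives > 100000 nM, which is a limit of the assay and not a number. On this second core the nitro group gave a number no higher from compound 2 to compound 4 (the limit leaves the size open), so it did not repeat the rise seen on the core of compound 1: the same change on two cores in this assay, a 4.4-fold higher number (0.65 log units; beyond the scatter) from compound 1 to compound 3 and a number no higher (the limit leaves the size open) from compound 2 to compound 4, at least 4.4-fold (0.64 log units) apart, beyond the scatter of two such steps This shows that the step does not carry over unchanged between these two cores, but it does not show the true size of the step on the second core, nor why the two cores differ.

The compounds shown leave open whether an amine or a carboxylic acid in the place of the nitro group would shift the number alike on both cores.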